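Adding a methoxy group to compound 3

The source may report more compounds than this note shows. Statements on the series, on what has been measured and on what is new or still open speak of the compounds shown alone.

In an ADME assay on RAW264.7 cells (Mus musculus) for inhibition, read by MTT assay, with a stated time of 72 h, tested at 100 uM (on this read-out lower numbers stand for less inhibition of growth and higher numbers for more inhibition of growth at the one concentration tested), compound 3 `O=C(N/N=C(/N=N/c1ccccc1)c1ccccc1)c1cc(O)c(O)c(O)c1` gives 41.4%, level with compound 2 `Cc1ccccc1/N=N/C(=N/NC(=O)c1cc(O)c(O)c(O)c1)c1ccccc1` at 41.5%. Both stand under compound 1 `COc1ccccc1/N=N/C(=N/NC(=O)c1cc(O)c(O)c(O)c1)c1ccccc1` at 52.7%. Compound 4 `COc1ccc(/N=N/C(=N/NC(=O)c2cc(O)c(O)c(O)c2)c2ccccc2)cc1` differs from compound 3 by methoxy in place of hydrogen on an aromatic carbon, para to a large group. The closest measured change is a number 11.3 percentage points lower from compound 1 to compound 3 (beyond the scatter), the reverse swap, though with the methoxy at another place on the ring. The change involving methyl, a number 0.1 percentage points lower from compound 2 to compound 3 (within the scatter), says little about methoxy. Only part of the larger step is expected to carry over, so a smaller upward step is expected, a number 6.6 percentage points higher from compound 3 to compound 4 (within the scatter). Compound 4 is estimated at 48%, with an expected range of 38% to 60%.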

Compound 4, percent growth inhibition at one concentration: 15%
For compound 4 the middle estimate is 33 percentage points above the measured one; the measured number lies below the stated range.
By their numbers in this assay, from the lowest: compound 4; then compounds 3 and 2 (each within the scatter of the next); then compound 1.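

In this assay the change from phenyl to 4-methoxyphenyl gives a number 26.4 percentage points lower from compound 3 to compound 4 (beyond the scatter) and so shows that methoxy does not raise the number wherever it sits on the ring. Moving between the two methoxyphenyl groups gives a number 37.7 percentage points lower from compound 1 to compound 4 (beyond the scatter) as the largest step in the set, and 4-methoxyphenyl in place of 2-methylphenyl gives a number 26.5 percentage points lower from compound 2 to compound 4 (beyond the scatter) as a further fall. Nothing available here bears on why the number falls at this place. From the compounds shown here alone, whether an amine, a carboxylic acid or a longer chain such as ethoxy at this same place would go with a number as low as that of compound 4 stays open.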